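This account rests on a few compounds, and the source may have more. Where it says the series, first, only, none or still open, it means among the compounds named here.

Going by the values given here, compound 1 `O=C(N/N=C/c1ccc(F)cc1)Nc1ccc(Oc2ccnc3[nH]ccc23)c(F)c1` is examined in a functional assay on PC-3 cells (Homo sapiens) for antiproliferative activity, read by MTT assay, with a stated time of 72 h (on this read-out higher numbers stand for weaker inhibition and lower numbers for stronger inhibition), where compound 1 gives 2330 nM; among the three compounds measured so far this is the second highest number. Compound 2 `O=C(N/N=C/c1cccc([N+](=O)[O-])c1)Nc1ccc(Oc2ccnc3[nH]ccc23)c(F)c1` gives 5140 nM in this assay, and compound 3 `O=C(N/N=C/c1ccc([N+](=O)[O-])cc1)Nc1ccc(Oc2ccnc3[nH]ccc23)c(F)c1` gives 150 nM. The step of a 2.2-fold higher number from compound 1 to compound 2 (0.34 log units; beyond the scatter) is modest, while the step of a 16-fold lower number from compound 1 to compound 3 (1.19 log units; beyond the scatter) is large, and the step of a 34-fold lower number from compound 2 to compound 3 (1.53 log units; beyond the scatter) shows how strongly the numbers at this position depend on which group sits on the carbon with a double bond to nitrogen.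

Compound 4 `O=C(N/N=C/c1cc(Br)c(O)c(Br)c1)Nc1ccc(Oc2ccnc3[nH]ccc23)c(F)c1` has not yet been measured. It differs from compound 1 as follows: 3,5-dibromo-4-hydroxyphenyl in place of 4-fluorophenyl on a carbon with a double bond to nitrogen. Among the compounds with values here, no measured step introduces a hydroxy or bromine group at this ring, so the two steps from compound 1 give only an indirect guide: they show that exchanging the group on this carbon can move the number in this assay either way, modestly upward as in compound 2 or strongly downward as in compound 3. Compound 4 is therefore expected to give 1200 nM in this assay, within a range from 250 nM to 6000 nM. The expected step from compound 1 is a 1.9-fold lower number from compound 1 to compound 4 (0.29 log units; within the scatter), with wide uncertainty.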

Compound 4, half-maximal inhibitory concentration: "not active" (no number reported)
The entry for compound 4 holds no number, and the estimate cannot be compared.
By their numbers in this assay, from the lowest: compound 3; then compound 1; then compound 2.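

In this assay, going by these compounds alone, compound 4 is reported as "not active" without a number, so no step between it and compound 1, compound 2 or compound 3 can be read. As far as these compounds go, how far compound 4 lies from compound 1 stays open, as does which part of the 3,5-dibromo-4-hydroxyphenyl group matters. Nothing shown here explains this result.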